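The source may report more compounds than this note shows. Statements on the series, on what has been measured and on what is new or still open speak of the compounds shown alone.

Compound 1 `CCCCCCCCCCCCCCCCCC(=O)Nc1nnc(S[C@@H]2O[C@H](COC(C)=O)[C@H](OC(C)=O)[C@H](OC(C)=O)[C@H]2OC(C)=O)s1` is one of three compounds examined in a functional assay on SK-OV-3 cells (Homo sapiens) for cytotoxicity, read by MTT assay, with a stated time of 24 h; on this read-out lower numbers stand for stronger inhibition and higher numbers for weaker inhibition. In that assay compound 1 is reported as "not active" (no number reported), without a number. Compound 3 `CCCCCCCCCCCCCCCCCC(=O)Nc1nnc(S[C@@H]2O[C@H](CO)[C@H](O)[C@H](O)[C@H]2O)s1`, which carries the same long acyl chain but free hydroxyl groups on the sugar, is likewise reported in this assay as "not active" (no number reported). Among the compounds with values here, the only numerical value among the three belongs to compound 2 `CCCCCCCC(=O)Nc1nnc(S[C@@H]2O[C@H](CO)[C@H](O)[C@H](O)[C@H]2O)s1`, with a shorter acyl chain on the free sugar; in this assay compound 2 gives 56000 nM, a weak result. Within the data shown here, no two measured compounds differ in a single place, so no step can be computed among them; all that can be said is that the two long-chain compounds returned no number, while the short-chain compound returned a high value.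

Compound 4 `CCCCCCCC/C=C\CCCCCCCCCCCC(=O)Nc1nnc(S[C@@H]2O[C@H](COC(C)=O)[C@H](OC(C)=O)[C@H](OC(C)=O)[C@H]2OC(C)=O)s1` is not yet measured in this assay. It differs from compound 1 as follows: dec-1-en-1-yl in place of hexyl on a saturated chain carbon, ten or more bonds along the chain from a carbonyl carbon. Since compound 1 itself gave no number, there is no baseline from which to compute a step, and the expectation for compound 4 rests on the absence of activity seen for compound 1 and compound 3. Compound 4 is therefore expected to be weak, with an estimated value of 150000 nM and a range from 50000 nM to 500000 nM, and most likely to be reported again only as not active.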

Compound 4, half-maximal inhibitory concentration: "not active" (no number reported)
The entry for compound 4 holds no number, and the estimate cannot be compared.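

Compound 1 gives "not active" (no number reported) in this assay and compound 4 gives "not active" (no number reported) there, and neither entry holds a number, so no step can be read between them. No measured evidence bears on this result. The compounds shown leave open whether dec-1-en-1-yl in place of hexyl alters cytotoxicity at all.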